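The compounds below may be only part of what the source reports. "The series", "measured", "known", "first", "only" and "open" are said of these compounds alone.

Compound 1 `CSc1nnc(Cc2ccc(Cl)cc2Oc2ccccc2F)[nH]1`: 136%
Compound 2 `CCSc1nnc(Cc2ccc(Cl)cc2Oc2ccccc2F)[nH]1`: 141%
Compound 3 `Nc1nnc(Cc2ccc(Cl)cc2Oc2ccccc2Cl)o1`: 170%

In a functional assay on the whole organism (strain NMRI) with Mus musculus as the target, with a stated time of 60 min, at a dose of 20 mg/kg by the intraperitoneal route (on this read-out lower numbers stand for a weaker effect and higher numbers for a stronger effect at the one dose given), compound 3 gives 170%, the highest of the three numbers; compound 2 stands nearest with 141% and compound 1 furthest with 136%, both gaps lying beyond the scatter. Compound 4 `Nc1nnc(Cc2ccc(Cl)cc2Oc2ccccc2F)o1` has not yet been measured in this assay. It differs from compound 3 in one place: fluoro in place of chloro on an aromatic carbon. Read one bond further out, the change is 2-chlorophenyl to 2-fluorophenyl, on an aromatic carbon of a six-membered aromatic ring of carbon only, ortho to a large group.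

Among the compounds with values here, only one measured step exists, a number 5 percentage points higher from compound 1 to compound 2 (within the scatter), and it concerns a methyl in place of hydrogen on a saturated chain carbon bound to a sulfur; it does not touch the change in hand. Within the data shown here, no measured pair shows fluoro in place of chloro on its own. Among the measured compounds shown here, compounds 1 and 2 carry the same fluoro as compound 4, but they also differ from compound 3 in the core, so their values show only that two fluoro-bearing compounds of another core fall below compound 3. The step from compound 3 to compound 4 is therefore expected to be small and downward, at most a modest drop, a number 20 percentage points lower from compound 3 to compound 4 (beyond the scatter). Compound 4 is estimated to give 150% in this assay, with a range from 115% to 185%.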

Compound 4, a percentage reported as activity, at one dose (the size of the read-out at that dose, not a potency): 154%
The estimate for compound 4 lay 4 percentage points below the measured number; the measured number falls inside the stated range.
By their numbers in this assay, from the lowest: compounds 1 and 2 (each within the scatter of the next); then compound 4; then compound 3.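

In this assay the change from 2-chlorophenyl to 2-fluorophenyl, on an aromatic carbon ortho to a large group, now has a measured size of its own: a number 16 percentage points lower from compound 3 to compound 4 (beyond the scatter). This shows that the read-out responds to which halogen sits at this position, though the step is modest and compound 4 keeps a high number with fluoro in place of chloro. With the 2-fluorophenyl held constant, the group on the saturated chain carbon also proves to matter, as shown by a number 13 percentage points higher from compound 2 to compound 4 (beyond the scatter) and by a number 18 percentage points higher from compound 1 to compound 4 (beyond the scatter), so the lower numbers of the two sulfur-bearing compounds are not explained by the fluoro alone, and nothing measured here gives a reason for any of these steps.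

The compounds shown leave open how a 2-bromophenyl, a 2-methoxyphenyl or an unsubstituted phenyl would read in place of these two rings, and whether fluoro in place of chloro would give a step of similar size on the core of compound 1. They also leave open what a dimethylamino group or a longer chain would give in place of the amine of compound 4.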